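A few compounds are considered here, and "the series" means these few. Any claim that something is new, unique, unknown or untested is made for them only; others in the source may bear on it.

Working notes on the series. Compound 2 `CC1=NN(c2ccc(C)cc2)C(=O)C12C=CC(=O)C=C2c1ccc(C)cc1` gives 9710 nM in a functional assay on HCT-116 cells (Homo sapiens) for antiproliferative activity, read by CCK-8 assay, with a stated time of 72 h; a higher number here means a weaker inhibitor, a lower number a stronger inhibitor. Compound 1 `CC1=NN(c2ccc(C)cc2)C(=O)C12C=CC(=O)C=C2c1cccc(C)c1` carries the change (3-methylphenyl in place of 4-methylphenyl on a double-bonded ring carbon); in this assay compound 1 gives 8340 nM, and the step is a 1.2-fold lower number from compound 2 to compound 1 (0.07 log units; within the scatter). Compound 3 `CC1=NN(c2ccc(Br)cc2)C(=O)C12C=CC(=O)C=C2c1ccc(C)cc1` differs from compound 2 by bromo in place of methyl on an aromatic carbon; in this assay compound 3 gives 10600 nM, and the step is a 1.1-fold higher number from compound 2 to compound 3 (0.04 log units; within the scatter). Compound 4 `CC1=NN(c2ccc(Br)cc2)C(=O)C12C=CC(=O)C=C2c1cccc(C)c1` is not yet measured in this assay. It differs from compound 3 by 3-methylphenyl in place of 4-methylphenyl on a double-bonded ring carbon, the same change as from compound 2 to compound 1, on the core that carries bromo in place of methyl. Because the earlier step of a 1.2-fold lower number from compound 2 to compound 1 (0.07 log units; within the scatter) stayed within the scatter, the expected step is a 1.2-fold lower number from compound 3 to compound 4 (0.07 log units; within the scatter). On that basis compound 4 is estimated at 9000 nM in this assay, with the likely range running from 5500 nM to 15000 nM.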

Compound 4, half-maximal inhibitory concentration: > 100000 nM
Compound 4 gave a limit, no number (the forecaster's own chance of this, stated with the estimate: 5%); at least 11-fold (1.04 log units) between middle value and limit.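

In this assay compound 4 gives > 100000 nM, which is a limit of the assay and not a number. The change to 3-methylphenyl in place of 4-methylphenyl does not carry from one core to the other, as an at least 9.4-fold higher number from compound 3 to compound 4 (0.97 log units; beyond the scatter) shows: the same change on two cores in this assay, a 1.2-fold lower number (0.07 log units; within the scatter) from compound 2 to compound 1 and an at least 9.4-fold higher number (0.97 log units; beyond the scatter) from compound 3 to compound 4, at least 10-fold (1.04 log units) apart, beyond the scatter of two such steps The bromo change, an at least 11-fold higher number from compound 1 to compound 4 (1.07 log units; beyond the scatter), does not carry either, but this shows only that the two changes are not independent across these four compounds, not how large either step truly is: the same change on two cores in this assay, a 1.1-fold higher number (0.04 log units; within the scatter) from compound 2 to compound 3 and an at least 11-fold higher number (1.07 log units; beyond the scatter) from compound 1 to compound 4, at least 10-fold (1.04 log units) apart, beyond the scatter of two such steps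

On these data alone, it remains open whether the same break appears on the core of compound 1 when methyl on the aromatic carbon is replaced by chloro or methoxy rather than bromo. As far as these compounds go, it also remains open whether an amine on the 3-methylphenyl ring would behave the same way.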